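Chloro to Methoxy: An Untested Step in Cytotoxicity

This account rests on a few compounds, and the source may have more. Where it says the series, first, only, none or still open, it means among the compounds named here.

In a functional assay on Ehrlich cells (Mus musculus) for cytotoxicity, read by trypan blue exclusion, with a stated time of 2 h, tested at 25 ug/mL (a lower number here means a stronger effect, a higher number a weaker effect of the compound at the concentration tested), compound 1 `N#Cc1c(N)[n+]([O-])c2ccc(Cl)cc2[n+]1[O-]` gives 65.1%, and compound 2 `Cc1c(C(=O)N=[N+]=[N-])[n+]([O-])c2cc(Cl)ccc2[n+]1[O-]` gives 84.2%. Compound 2 therefore holds the higher of the two numbers; its nearest neighbour is compound 1, which sits lower by a gap beyond the usual scatter, so compound 2 shows the weaker effect at the concentration tested. Compound 3 `COc1ccc2c(c1)[n+]([O-])c(C(=O)N=[N+]=[N-])c(C)[n+]2[O-]` differs from compound 2 in a single place: methoxy in place of chloro on an aromatic carbon. Going by the values given here, no measured pair of compounds shares this kind of change, so nothing in the data gives the size or direction of such a step. Because compound 2 gives 84.2% and the change is small in what it adds and removes, compound 3 is expected to stay close to it, with the expected step of a number 4.2 percentage points lower from compound 2 to compound 3 (within the scatter) lying within the scatter. Compound 3 is accordingly estimated at 80%, with a range from 62% to 95%.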

Compound 3, a percentage reported as activity, at one concentration (the size of the read-out at that concentration, not a potency): 11.3%
For compound 3 the middle estimate is 68.7 percentage points above the measured one; measured number outside the range, below it.
By their numbers in this assay, from the lowest: compound 3; then compound 1; then compound 2.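

In this assay, methoxy in place of chloro on this aromatic carbon gives a number 72.9 percentage points lower from compound 2 to compound 3 (beyond the scatter), so a change of only a few heavy atoms at this place can move the read-out a long way. The earlier compounds shown here could not show this, as they differ in more than one place and offered no step at all; this single pair now shows that the read-out is sensitive to what this carbon carries. Nothing available bears on what lies behind the step.

From the compounds shown here alone, whether an amine, a hydroxyl group or a longer chain such as ethoxy on the same carbon would give a step of similar size remains open. Going by these compounds alone, with only this one pair, it is also open whether the same change on the core of compound 1 would move the read-out in the same direction.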